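This account rests on a few compounds, and the source may have more. Where it says the series, first, only, none or still open, it means among the compounds named here.

Of the compounds shown here, three sharing one core have been measured in a functional assay on CCRF-CEM cells (Homo sapiens) for antiproliferative activity; a higher number here means a weaker inhibitor of growth, a lower number a stronger inhibitor of growth. Compound 1 `CC(C)(C)C(=O)OCC1(CO)C/C(=C\CCCCCCCCCCCO)C(=O)O1` gives 0.65 ug/mL, compound 2 `CCCCCOCCCCCCC/C=C1\CC(CO)(COC(=O)C(C)(C)C)OC1=O` gives 0.877 ug/mL, and compound 3 `CC(=O)OCCCCCCCCCCCCCCC/C=C1\CC(CO)(COC(=O)C(C)(C)C)OC1=O` gives 7.55 ug/mL, the highest number of the three, set apart by the steps of a 12-fold higher number from compound 1 to compound 3 (1.07 log units; beyond the scatter) and an 8.6-fold higher number from compound 2 to compound 3 (0.93 log units; beyond the scatter). Compound 4 `CC(C)(C)C(=O)OCCCCCCCCCCCCCCC/C=C1\CC(CO)(COC(=O)C(C)(C)C)OC1=O` differs from compound 3 by tert-butyl in place of methyl on a carbonyl carbon, on a carbonyl carbon whose other neighbours are oxygen next to a carbonyl group. Within the data shown here, no measured step alters that group: the steps of a 12-fold higher number from compound 1 to compound 3 (1.07 log units; beyond the scatter) and an 8.6-fold higher number from compound 2 to compound 3 (0.93 log units; beyond the scatter) brought in 4-acetoxybutyl and 8-acetoxyoctyl, which is a different change. With nothing to suggest otherwise, no step beyond the scatter is expected in this assay. Compound 4 is therefore estimated at 8 ug/mL, within 3 ug/mL to 20 ug/mL, an expected step of a 1.1-fold higher number from compound 3 to compound 4 (0.03 log units; within the scatter).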

Compound 4, concentration for 50% growth inhibition: > 10 ug/mL
Compound 4 ended at the assay's limit; the forecaster's own chance of this, stated with the estimate: 10%; middle value at least 1.2-fold (0.09 log units) from the limit.
By their numbers in this assay, from the lowest: compounds 1 and 2 (each within the scatter of the next); then compound 3. At a limit, above all of these: compound 4.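

In this assay compound 4 ended at a limit, not a number: the limit of > 10 ug/mL in this assay, at which 1 of the 4 values shown sits. At the carbonyl carbon, tert-butyl in place of methyl therefore gives only a floor, an at least 1.3-fold higher number from compound 3 to compound 4 (0.12 log units; that floor lies within the scatter), so the true size of this change cannot be read. With 4-(((tert-butyl)carbonyl)oxy)butyl in place of hydroxy, the step of an at least 15-fold higher number from compound 1 to compound 4 (1.18 log units; beyond the scatter) shows that this second ester also stands well beyond the scatter from the hydroxy end of compound 1, as the acetoxy end did in a 12-fold higher number from compound 1 to compound 3 (1.07 log units; beyond the scatter).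

Going by these compounds, how far compound 4 lies past the limit stays open. So does whether an amine or a carboxylic acid at the chain end would behave like the hydroxy.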